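The source may hold more compounds than are shown below. What is called first, only, known or untested is meant among the compounds shown, and "the series" means these compounds.

Working notes on the series. Compound 1 `Cn1ccc2cc(-c3ccc4oc(Nc5ccc(F)cc5)nc4c3)ccc21` gives 99 nM in an assay on HEK293 cells for inhibition of Fatty-acid amide hydrolase 1 (Homo sapiens), read by fluorescence; a lower number here means a stronger inhibitor, a higher number a weaker inhibitor. Compound 2 `Cn1ccc2cc(-c3ccc4oc(N5CCCC5)nc4c3)ccc21` gives 674 nM; the step of a 6.8-fold higher number from compound 1 to compound 2 (0.83 log units; beyond the scatter) is the largest seen. Compound 3 `C[C@@H]1CN(c2nc3cc(-c4ccc5c(ccn5C)c4)ccc3o2)C[C@H](C)O1` gives 168 nM, the second highest of the three numbers; the step of a 1.7-fold higher number from compound 1 to compound 3 (0.23 log units; within the scatter) is small, whereas a 4.0-fold lower number from compound 2 to compound 3 (0.60 log units; beyond the scatter) is clear. Compound 4 `Cn1ccc2cc(-c3ccc4oc(N5CCNCC5)nc4c3)ccc21` carries the change (piperazin-1-yl in place of 2,6-dimethylmorpholin-4-yl on an aromatic carbon). For the measured compounds named here, the steps that bear on it are the two exchanges at the same aromatic carbon, from compound 1 and from compound 2 to compound 3, one within the scatter and one modest. A ring of similar size enters, so the expected step of a 1.9-fold higher number from compound 3 to compound 4 (0.28 log units; within the scatter) is small, toward a somewhat higher number. Compound 4 is estimated at 320 nM, range 130 nM to 900 nM.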

Compound 4, half-maximal inhibitory concentration: > 1000 nM
Compound 4 ended at the assay's limit (the forecaster's own chance of this, stated with the estimate: 3%); middle value at least 3.1-fold (0.49 log units) from the limit.
By their numbers in this assay, from the lowest: compounds 1 and 3 (each within the scatter of the next); then compound 2. At a limit, above all of these: compound 4.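

Compound 4 stands at a limit of this assay, not at a number: the limit of > 1000 nM in this assay, at which 1 of the 4 values shown sits. Keeping a six-membered non-aromatic ring with 2 hetero atoms on this aromatic carbon does not keep the read-out, with an at least 5.9-fold higher number from compound 3 to compound 4 (0.77 log units; beyond the scatter); piperazin-1-yl has 1 hydrogen-bond donor where 2,6-dimethylmorpholin-4-yl has 0. For the compounds shown here, the exchange also gives an at least 10-fold higher number from compound 1 to compound 4 (1.00 log units; beyond the scatter), while an at least 1.4-fold higher number from compound 2 to compound 4 (0.17 log units; that floor lies within the scatter) is only a floor and gives no size for that step.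

From the compounds shown here alone, whether 4-methylpiperazin-1-yl or plain morpholin-4-yl would read nearer compound 3 or compound 4 stays open.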